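Alkyne-linked pyrimidines: alkyl versus amino substituent on the shared core

This account rests on a few compounds, and the source may have more. Where it says the series, first, only, none or still open, it means among the compounds named here.

Going by the values given here, compound 2 `CNc1ncc(C#Cc2cccc(C)c2)cn1` is the only member of this small series with a numeric read-out. In an assay on HEK293 cells for positive allosteric modulation of metabotropic glutamate receptor 5 (Rattus norvegicus) (on this read-out higher numbers stand for an effect only at larger amounts of compound and lower numbers for an effect already at smaller amounts), compound 2 gives 21100 nM, which puts it alone on the numbers shown, since the two other measured entries returned no single number. Compound 1 `CCc1ncc(C#Cc2ccc(C)cc2)cn1`, carrying an ethyl group on the shared core, is reported in this assay as "not active" (no number reported). Compound 3 `COc1ncc(C#Cc2ccccc2)cn1`, carrying a methoxy group there, is likewise reported as "not active" (no number reported).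

Compound 4 `Cc1cccc(C#Cc2cnc(C(C)(C)C)nc2)c1` has not been measured. It differs from compound 2 in one place: tert-butyl in place of methylamino on an aromatic carbon. Among the compounds with values here, no step between two measured compounds is available for this kind of change, so the expectation rests on the three entries above. Within the data shown here, the methylamino compound 2 is the only one with a number, while the alkyl-bearing compound 1 and the methoxy-bearing compound 3 gave none, so an entering tert-butyl is expected to move the read-out toward larger amounts of compound, or to leave compound 4 without a number at all. The expected step of a 1.7-fold higher number from compound 2 to compound 4 (0.22 log units; within the scatter) is modest, though it may well exceed the scatter. Compound 4 is estimated at 35000 nM, with a range from 12000 nM to 100000 nM.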

Compound 4, half-maximal effective concentration: "not active" (no number reported)
Nothing numeric was reported for compound 4, so the estimate cannot be set against anything.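

With no number for compound 4 in this assay to set against compound 2, no step can be read between the two. No measurement shown bears on a cause for this result. The compounds shown leave open how the read-out responds to a single change of group at this place on the shared core.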